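The source may hold more compounds than are shown below. What is called first, only, known or untested is meant among the compounds shown, and "the series" means these compounds.

In a functional assay on GC3/MTK- cells (Homo sapiens) for inhibition (a higher number here means a weaker inhibitor, a lower number a stronger inhibitor), compound 1 `C#CCN(Cc1ccc2nc(C)nc(O)c2c1)c1ccccc1` gives > 10700 nM, which is a limit of the assay and not a number. For the measured compounds named here, compound 2 `C#CCN(Cc1ccc2nc(C)nc(O)c2c1)c1ccc(C#N)cc1` gives 5000 nM, the only actual number so far. Cyano in place of hydrogen on an aromatic carbon accounts for an at least 2.1-fold lower number from compound 1 to compound 2 (0.33 log units; beyond the scatter). Compound 3 `C#CCN(Cc1ccc2nc(C)nc(O)c2c1)c1ccc(C(=O)c2ccccc2)cc1` carries benzoyl in place of cyano on an aromatic carbon, para to a large group: benzoyl in place of cyano on an aromatic carbon. That single measured step concerns the same place but not benzoyl, so no clear direction is expected, and the estimate is a 1.3-fold lower number from compound 2 to compound 3 (0.10 log units; within the scatter). Compound 3 is expected at 4000 nM, with an estimated range of 1200 nM to 13000 nM.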

Compound 3, half-maximal inhibitory concentration: 6200 nM
Beside the measured number, compound 3's estimate is 1.6-fold (0.19 log units) below it, and the stated range covers the measured number.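

In this assay, a group of eight heavy atoms with its own six-membered aromatic ring sits at this place with no change readable against the much smaller cyano, giving a 1.2-fold higher number from compound 2 to compound 3 (0.09 log units; within the scatter). Measured against hydrogen, benzoyl gives only an at least 1.7-fold lower number from compound 1 to compound 3 (0.23 log units; that floor lies within the scatter), so this step alone does not establish that benzoyl improves on hydrogen. Compound 1 stands at a limit and not a number: the limit of > 10700 nM in this assay, at which 1 of the 3 values shown sits.

Going by these compounds, what remains open is whether an amine or a carboxylic acid at this place would separate from cyano and benzoyl beyond the scatter. On these data alone, it is equally open whether a longer chain in place of the aromatic ring of benzoyl would do so.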